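Replacing a chlorophenyl sulfonyl amino group with hydroxymethyl

The compounds below may be only part of what the source reports. "The series", "measured", "known", "first", "only" and "open" are said of these compounds alone.

Compound 1 `Cc1ccc(-c2cn(C/C=C3\OC(=O)C(OCc4ccccc4)=C3OCc3ccccc3)nn2)cc1`: 7480 nM
Compound 2 `CC(C)(C)OC(=O)N1CCN(C(=S)SCc2cn(C[C@H](O)[C@H]3OC(=O)C(OCc4ccccc4)=C3OCc3ccccc3)nn2)CC1`: > 100000 nM (a limit)
Compound 3 `O=C1O[C@H]([C@@H](O)Cn2cc(CNS(=O)(=O)c3ccc(Cl)cc3)nn2)C(OCc2ccccc2)=C1OCc1ccccc1`: 13600 nM

In a functional assay on HeLa cells (Homo sapiens) for antiproliferative activity, read by MTT assay, with a stated time of 72 h (a higher number here means a weaker inhibitor, a lower number a stronger inhibitor), compound 3 gives 13600 nM and compound 1 gives 7480 nM, two numbers that lie within the scatter of each other. Compound 2 reports only a limit, not a number. Compound 4 `O=C1O[C@H]([C@@H](O)Cn2cc(CCO)nn2)C(OCc2ccccc2)=C1OCc1ccccc1` has not yet been measured. It carries hydroxymethyl in place of ((4-chlorophenyl)sulfonyl)amino on a saturated chain carbon bound to an aromatic carbon. Among the measured compounds shown here, no measured pair isolates this change, so the size of the step remains a judgement. Compound 3, at 13600 nM, loses a six-membered aromatic ring of carbon only with the group that leaves, and a modest weakening is therefore expected in this assay, not a large one. The estimated move is a 2.2-fold higher number from compound 3 to compound 4 (0.34 log units; beyond the scatter), only a little beyond the scatter. For compound 4 the expected value is 30000 nM, with an estimated range of 8000 nM to 100000 nM.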

Compound 4, half-maximal inhibitory concentration: 68800 nM
Estimate against measurement, compound 4: 2.3-fold (0.36 log units) below; low and high end bracket the measured number.
By their numbers in this assay, from the lowest: compounds 1 and 3 (each within the scatter of the next); then compound 4. At a limit, above all of these: compound 2.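

In this assay, hydroxymethyl in place of ((4-chlorophenyl)sulfonyl)amino on a saturated chain carbon bound to an aromatic carbon gives a 5.1-fold higher number from compound 3 to compound 4 (0.70 log units; beyond the scatter), the only step among the compounds shown that can be read at this place. It shows that the number responds to what this place carries, and that the change, which removes a six-membered aromatic ring of carbon only, comes with weaker activity. Compound 2 stands only at a limit of the assay, not at a number: the limit of > 100000 nM in this assay, at which 1 of the 4 values shown sits.

Which part of the group that leaves accounts for the step stays open: a simple amine, a carboxylic acid or a phenyl group at this place would each bear on that. On these data alone, whether the same exchange would move the number similarly on another core also remains open.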